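The source may hold more compounds than are shown below. What is called first, only, known or untested is meant among the compounds shown, and "the series" means these compounds.

Within the data shown here, compound 2, with the structure `CCCCCC(=O)N[C@@H]1CCN(c2cc(C)nn3c(-c4ccc(OC)c(OC)c4)c(C)nc23)C1`, is one of two compounds measured in an ADME assay on microsomes from liver (Homo sapiens) for metabolic stability, read by LC-MS, with NADPH named in the record, with a stated time of 60 min, tested at 1 uM, in the absence of a further agent; on this read-out lower numbers stand for a less stable compound and higher numbers for a more stable compound. In this assay compound 2 gives > 95%, which is a limit of the assay and not a number. The other compound, compound 1, with the structure `CC(=O)N[C@@H]1CCN(c2cc(C)nn3c(-c4cccs4)c(C)nc23)C1`, is measured in the same assay; in this assay compound 1 gives > 95%, again a limit rather than a number. Because of the limit of > 95% in this assay, at which 2 of the 2 values shown sit, compound 2 cannot be placed above or below compound 1; both simply sit at the limit.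

Compound 3, with the structure `COc1ccc(-c2c(C)nc3c(N4CC[C@@H](n5cc(-c6ccccc6)nn5)C4)cc(C)nn23)cc1OC`, has not yet been measured in this assay. It differs from compound 2 in one place: 4-phenyl-1H-1,2,3-triazol-1-yl in place of (pentylcarbonyl)amino on a saturated ring carbon. The pentylcarbonylamino group on the saturated ring carbon leaves, and a 4-phenyl-1H-1,2,3-triazol-1-yl group enters at that carbon.

Among the measured compounds shown here, with no measured step between two compounds to lean on, the step from compound 2 to compound 3 is expected to be a loss of moderate size, beyond the scatter, as a number at least 10 percentage points lower from compound 2 to compound 3 (that floor lies within the scatter), since the limit of compound 2 leaves no room for a gain. Compound 3 is therefore estimated to give about 85% in this assay, within a range from 60% to 95%.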

Compound 3, percent of the compound remaining: "unstable" (no number reported)
No number was reported for compound 3; no gap can be computed for the estimate.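

In this assay compound 3 gives "unstable" (no number reported), with no number reported. Among these compounds, no step from compound 2 to compound 3 can be read, because compound 3 has no number to set against a limit: the limit of > 95% in this assay, at which 2 of the 3 values shown sit. The compounds shown leave open how large the difference between compound 2 and compound 3 is, and whether the exchange of groups alone accounts for it.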